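Para substituent swap on the urea series: butyl to fluoro

The source may hold more compounds than are shown below. What is called first, only, known or untested is meant among the compounds shown, and "the series" means these compounds.

Among the measured compounds shown here, compound 2 `CCCCc1ccc(NC(=O)N[C@H](C)c2ccccc2)cc1` gives 28% in an ADME assay on the whole organism with Oryza sativa as the target, tested at 10 uM (a lower number here means a stronger effect, a higher number a weaker effect of the compound at the concentration tested), the lowest of the three numbers measured so far. Its stereoisomer compound 3 `CCCCc1ccc(NC(=O)N[C@@H](C)c2ccccc2)cc1` gives 60%, and compound 1 `Cc1ccccc1NC(=O)N[C@@H](C)c1ccccc1` gives 99%. For the measured compounds named here, the only single-place step recorded is a number 32 percentage points higher from compound 2 to compound 3 (beyond the scatter), attributable to the fact that compounds 2 and 3 differ only in the configuration as drawn, and it concerns configuration rather than the ring substituent. Compound 4 `C[C@@H](NC(=O)Nc1ccc(F)cc1)c1ccccc1` keeps the configuration of compound 2 and differs by fluoro in place of butyl on an aromatic carbon. Going by the values given here, no measured step tests this change, so the expectation rests on the spread of the three numbers alone. A move upward is expected, a number 32 percentage points higher from compound 2 to compound 4 (beyond the scatter), with wide uncertainty. Compound 4 is estimated at 60%, in the range 30% to 95%.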

Compound 4, a percentage reported as activity, at one concentration (the size of the read-out at that concentration, not a potency): 92%
The estimate for compound 4 lay 32 percentage points below the measured number; the measured number falls inside the stated range.
By their numbers in this assay, from the lowest: compound 2; then compound 3; then compounds 4 and 1 (each within the scatter of the next).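

Fluoro in place of butyl on an aromatic carbon, para to a large group, gives a number 64 percentage points higher from compound 2 to compound 4 (beyond the scatter) in this assay. Among the compounds shown here, this is the first step at the ring substituent rather than at configuration, and with the configuration held it is large. Nothing at hand accounts for this step.

As far as these compounds go, whether the number tracks chain length at this place stays open, and an ethyl or a hexyl group there would test it. From the compounds shown here alone, whether configuration still matters with fluoro in place of butyl is also open.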